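Adding a Third Methoxy Group: From Compound 2 to Compound 3

The compounds below may be only part of what the source reports. "The series", "measured", "known", "first", "only" and "open" are said of these compounds alone.

Of the compounds shown here, two built on a shared core have so far been measured in a functional assay on HeLa cells (Homo sapiens) for cytotoxicity, read by MTT assay, with a stated time of 48 h; a lower number here means a stronger inhibitor, a higher number a weaker inhibitor. Compound 1 `COc1ccc2nc(NC(=O)c3cc(-c4ccc(F)cc4)n4nc(-c5ccccc5)cc4n3)sc2c1` gives 17300 nM. Compound 2 `COc1ccc2nc(NC(=O)c3cc(-c4ccc(OC)c(OC)c4)n4nc(-c5ccccc5)cc4n3)sc2c1` gives 11000 nM. Going by the values given here, the one change between them reads as a 1.6-fold lower number from compound 1 to compound 2 (0.20 log units; within the scatter). Compound 2 thus holds the lower of the two numbers, but its gap to compound 1 falls within the scatter, so no order between the two can be read from these values.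

Compound 3 `COc1ccc2nc(NC(=O)c3cc(-c4cc(OC)c(OC)c(OC)c4)n4nc(-c5ccccc5)cc4n3)sc2c1` has not yet been measured. It differs from compound 2 in a single place: methoxy in place of hydrogen on an aromatic carbon. Among the compounds with values here, the only measured step that bears on this change is a 1.6-fold lower number from compound 1 to compound 2 (0.20 log units; within the scatter), where two methoxy groups entered together on the same aromatic ring without carrying the number beyond the scatter. A third methoxy group entering on an aromatic carbon is expected to behave much the same, so the expected step is small and of no firm direction, a 1.2-fold lower number from compound 2 to compound 3 (0.09 log units; within the scatter). Compound 3 is accordingly estimated to give about 9000 nM, within a range from 4000 nM to 22000 nM.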

Compound 3, half-maximal inhibitory concentration: 8700 nM
The estimate for compound 3 lay 1.0-fold (0.01 log units) above the measured number, and the stated range covers the measured number.
By their numbers in this assay, from the lowest: compounds 3, 2 and 1 (each within the scatter of the next).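

Compound 3 shows that the carbon ortho to a methoxy group and meta to a large group, on the six-membered aromatic ring of carbon only, can carry a further methoxy group without the number in this assay leaving the scatter, with a 1.3-fold lower number from compound 2 to compound 3 (0.10 log units; within the scatter). The earlier compounds shown here tested only the 3,4-dimethoxyphenyl group, so they could not show what the 3,4,5-trimethoxyphenyl group would give. Even the whole replacement of the 4-fluorophenyl group reads as a 2.0-fold lower number from compound 1 to compound 3 (0.30 log units; within the scatter), so this fuller pattern of methoxy groups still does not separate the compounds, and no order among the three can be drawn from these values.

On these data alone, it remains open whether a group of another kind on this carbon, such as an amine, a carboxylic acid or a longer chain like ethoxy in place of methoxy, would carry the number beyond the scatter, and whether changes elsewhere on the shared core would do so. Nothing further is available to explain why these numbers lie so close together.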